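The source may hold more compounds than are shown below. What is called first, only, known or untested is meant among the compounds shown, and "the series" means these compounds.

compound 1 `O=c1[nH]c(CCc2ccccc2)no1`: 0.32
compound 2 `O=C1NC(=O)C(Cc2ccccc2)O1`: -0.16
compound 3 `CC1=C(O)CC(Cc2ccccc2)C1=O`: -0.33

In a physicochemical assay for lipophilicity, read by LC-MS, using the shake flask method, with a stated time of 1 h, at pH 7.4 (a lower number here means a more polar compound, a higher number a more lipophilic compound), compound 3 stands level with compound 2, within the usual scatter, and clearly under compound 1. These three compounds differ in more than one place, and none of them shows directly what a single small change does to the number.

Compound 4 `O=C1C=C(O)CC1Cc1ccccc1` differs from compound 3 in one place: hydrogen in place of methyl on a double-bonded ring carbon. A modest move to a lower number in this assay is expected, probably just beyond the scatter. The expected change is a number 0.42 log units lower from compound 3 to compound 4 (beyond the scatter). For compound 4 the estimated value is -0.75, with an expected range from -1.2 to -0.35.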

Compound 4, distribution coefficient: -0.7
For compound 4 the middle estimate is 0.05 log units below the measured one; measured number inside the range.
By their numbers in this assay, from the lowest: compound 4; then compounds 3 and 2 (each within the scatter of the next); then compound 1.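

In this assay, going by these compounds alone, hydrogen in place of methyl on a double-bonded ring carbon gives a number 0.37 log units lower from compound 3 to compound 4 (beyond the scatter) and this is the first step here that changes one place only. It shows that this position alone can shift the number beyond the scatter, though only a single carbon leaves. The data offer no explanation for the shift.

As far as these compounds go, whether an ethyl group, a fluorine or an amine at this position would move the number further, or the other way, remains open. So does whether the same exchange behaves alike at another ring position.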